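The source may hold more compounds than are shown below. What is called first, only, known or untested is meant among the compounds shown, and "the series" means these compounds.

- compound 1 `CCOC(=O)c1ccc(-c2nn(Cc3ccccc3F)c3ccccc23)cc1`: 110 nM
- compound 2 `CCOC(=O)c1ccc(-c2nn(Cc3cccc(OC)c3)c3ccccc23)cc1`: 260 nM

In a functional assay on cells (Platelet, Homo sapiens) for inhibition (on this read-out lower numbers stand for stronger inhibition and higher numbers for weaker inhibition), compound 1 holds the lower of the two numbers, and the gap to compound 2 lies beyond the scatter. Compound 3 `CCOC(=O)c1ccc(-c2nn(Cc3ccncc3)c3ccccc23)cc1` has not yet been measured. It carries pyridin-4-yl in place of 2-fluorophenyl on a saturated chain carbon bound to an aromatic nitrogen. Within the data shown here, one measured step bears on this change, because it replaces the same ring at the same place: a 2.4-fold higher number from compound 1 to compound 2 (0.37 log units; beyond the scatter). That step is modest. Neither measured compound has a hetero atom in this ring, so the data say nothing direct about pyridin-4-yl. A step of similar or somewhat larger size towards a higher number is therefore expected, with the estimate reading a 3.6-fold higher number from compound 1 to compound 3 (0.56 log units; beyond the scatter). For compound 3 the expected value is 400 nM, with an estimated range from 130 nM to 1500 nM.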

Compound 3, half-maximal inhibitory concentration: 5630 nM
For compound 3 the middle estimate is 14-fold (1.15 log units) below the measured one; measured number above the stated range.
By their numbers in this assay, from the lowest: compound 1; then compound 2; then compound 3.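

In this assay, the ring on a saturated chain carbon bound to an aromatic nitrogen can shift the read-out much further than the earlier pair showed: pyridin-4-yl in place of 2-fluorophenyl gives a 51-fold higher number from compound 1 to compound 3 (1.71 log units; beyond the scatter), and pyridin-4-yl in place of 3-methoxyphenyl gives a 22-fold higher number from compound 2 to compound 3 (1.34 log units; beyond the scatter). Both steps are large, whereas the exchange between the two substituted carbon-only rings was modest, so among these three compounds the pyridin-4-yl ring stands apart. No measurement at hand offers a reason for this gap.

Compound 3 differs from the other two both in its ring nitrogen and in lacking a ring substituent, and an unsubstituted phenyl ring would help separate the two. From the compounds shown here alone, whether pyridin-2-yl or pyridin-3-yl behaves like pyridin-4-yl also remains open.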